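Aryl swaps on the benzylamino adenosine series: compound 4 forecast

This account rests on a few compounds, and the source may have more. Where it says the series, first, only, none or still open, it means among the compounds named here.

Measured so far in a functional assay on HL-60 cells (Homo sapiens) for antiproliferative activity, with a stated time of 72 h; a higher number here means a weaker inhibitor, a lower number a stronger inhibitor:
Compound 1 `OC[C@H]1O[C@@H](n2cnc3c(NCc4ccc(F)cc4)ncnc32)[C@H](O)[C@@H]1O` gives 1200 nM.
Compound 2 `COc1ccccc1CNc1ncnc2c1ncn2[C@@H]1O[C@H](CO)[C@@H](O)[C@H]1O` gives 2300 nM.
Compound 3 `OC[C@H]1O[C@@H](n2cnc3c(NCc4ccc(Cl)c(Cl)c4)ncnc32)[C@H](O)[C@@H]1O` gives 2000 nM.

All three share the same core and differ only in the aryl group on a saturated chain carbon bound to a nitrogen on an aromatic ring. None of the swaps moved the number: a 1.9-fold higher number from compound 1 to compound 2 (0.28 log units; within the scatter); a 1.7-fold higher number from compound 1 to compound 3 (0.22 log units; within the scatter); a 1.2-fold lower number from compound 2 to compound 3 (0.06 log units; within the scatter). Compound 3 therefore sits among the others, its gaps to compound 2 and to compound 1 both inside the usual spread of repeats.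

Compound 4 `COc1cccc(CNc2ncnc3c2ncn3[C@@H]2O[C@H](CO)[C@@H](O)[C@H]2O)c1O` is the next aryl variant. Its difference from compound 3: 2-hydroxy-3-methoxyphenyl in place of 3,4-dichlorophenyl on a saturated chain carbon bound to a nitrogen on an aromatic ring

The three measured steps all concern the same place and the same kind of change, an aryl group exchanged for another, and each was within the scatter. For the measured compounds named here, no measured step involves a group carrying a hydrogen-bond donor, so the entering 2-hydroxy-3-methoxyphenyl has no direct precedent here. On the evidence available, the step in this assay from compound 3 to compound 4 is expected to be small, no change at the digits printed from compound 3 to compound 4 (within the scatter), with no clear direction. Compound 4 is therefore estimated at 2000 nM, within 800 nM to 5000 nM.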

Compound 4, half-maximal inhibitory concentration: 150 nM
Beside the measured number, compound 4's estimate is 13-fold (1.12 log units) above it, and the stated range ends above it.
By their numbers in this assay, from the lowest: compound 4; then compounds 1, 3 and 2 (each within the scatter of the next).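

At this place, on a saturated chain carbon bound to a nitrogen on an aromatic ring, the aryl group can set the level in this assay: 2-hydroxy-3-methoxyphenyl gives a 13-fold lower number from compound 3 to compound 4 (1.12 log units; beyond the scatter) and a 15-fold lower number from compound 2 to compound 4 (1.19 log units; beyond the scatter) and also an 8.0-fold lower number from compound 1 to compound 4 (0.90 log units; beyond the scatter) where every earlier aryl exchange stayed within the scatter. Compound 2 also carries a methoxy group yet stays within the scatter of compound 1 and compound 3, so a methoxy group alone does not go with the lower number, and compound 4 is the only compound shown whose aryl group carries a hydrogen-bond donor. Nothing available gives a reason for the size of these steps.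

The compounds shown do not separate the hydroxy group from the methoxy group within 2-hydroxy-3-methoxyphenyl, so it remains open whether a simple hydroxyphenyl group would keep the lower number. Going by these compounds, it is also open whether an aminophenyl group or a benzoic acid ring, each carrying its amine or carboxylic acid in place of the hydroxy group, would hold the number at the level of compound 4 or return it to that of the other three.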